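Cyclohexanediamide series: aryl swap on one carbonyl

The source may hold more compounds than are shown below. What is called first, only, known or untested is meant among the compounds shown, and "the series" means these compounds.

Measured so far:
compound 1 `N#Cc1cccc(C(=O)N[C@@H]2CCC[C@@H](NC(=O)c3ccccn3)C2)c1` — 1280 nM
compound 2 `O=C(N[C@@H]1CCC[C@@H](NC(=O)c2ccccn2)C1)c1cccc(Cl)c1` — 205 nM
compound 3 `O=C(N[C@H]1CCC[C@H](NC(=O)c2cccc(Cl)c2)C1)c1ccncc1` — 445 nM

In an assay on HEK293 cells for displacement of a labelled ligand from metabotropic glutamate receptor 5 (Homo sapiens), read by scintillation counting, with a stated time of 60 min (on this read-out higher numbers stand for weaker inhibition and lower numbers for stronger inhibition), compound 3 sits second highest of the three numbers, a little above compound 2 and well below compound 1. Compound 4 `O=C(N[C@H]1CCC[C@H](NC(=O)c2ccccc2F)C1)c1cccc(Cl)c1` differs from compound 3 by 2-fluorophenyl in place of pyridin-4-yl on a carbonyl carbon. Among the compounds with values here, no measured step touches this position; the only recorded single-point change, a 6.2-fold lower number from compound 1 to compound 2 (0.80 log units; beyond the scatter), concerns the other amide and gives no direct read on replacing a pyridinyl with a fluorophenyl. Compound 2 and compound 3 differ at more than one place, so their gap cannot be assigned. With little to go on, compound 4 is expected to land near compound 3, with a 1.3-fold lower number from compound 3 to compound 4 (0.10 log units; within the scatter) as the working guess and wide uncertainty. The estimate for compound 4 is 350 nM (range 120 nM to 1000 nM).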

Compound 4, inhibition constant: 760 nM
The estimate for compound 4 lay 2.2-fold (0.34 log units) below the measured number; low and high end bracket the measured number.
By their numbers in this assay, from the lowest: compound 2; then compounds 3, 4 and 1 (each within the scatter of the next, the first and the last beyond it).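

On this carbonyl carbon, an aromatic ring with a hetero atom and a hydrogen-bond acceptor gives way to a carbon-only ring bearing fluorine, and this assay shows a 1.7-fold higher number from compound 3 to compound 4 (0.23 log units; within the scatter). The position therefore accepts both pyridin-4-yl and 2-fluorophenyl, with no separation between them on this read-out. Nothing at hand gives a reason for this result.

Still open, from the compounds shown here alone, is how a non-aromatic group on this carbonyl carbon, such as an amine or a carboxylic acid, would read. Also open, going by these compounds, is whether the same exchange reads alike with a different group on the other amide.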